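From ethoxy to propyl in a cytotoxicity series

This account rests on a few compounds, and the source may have more. Where it says the series, first, only, none or still open, it means among the compounds named here.

Values measured in a toxicity assay on MDCK cells (Canis lupus familiaris) for cytotoxicity, read by CCK-8 assay, with a stated time of 48 h; a lower number here means that less compound is tolerated, a higher number that more compound is tolerated:
Compound 1 `CCCOc1ccc(C(=O)NNc2c(Br)cccc2Br)cc1`: > 100000 nM
Compound 2 `CCOc1ccc(C(=O)NNc2c(Cl)cccc2Cl)cc1`: > 100000 nM
Compound 3 `CCOc1ccc(C(=O)N(C)Nc2c(Cl)cccc2Cl)cc1`: > 100000 nM

Compound 2 stands at > 100000 nM, which is a limit of the assay and not a number. It has no number to be ranked by, since the three measured compounds share (the limit of > 100000 nM in this assay, at which 3 of the 3 values shown sit).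

The step followed here puts propyl in place of ethoxy on an aromatic carbon, para to a large group, and leads to compound 4 `CCCc1ccc(C(=O)NNc2c(Cl)cccc2Cl)cc1`: propyl in place of ethoxy on an aromatic carbon.

Only a step that the two limits leave unreadable from compound 2 to compound 3 bears on this change, and it lies at another place in the molecule, so no size carries over and no step beyond the scatter, in either direction, is expected in this assay. The estimate amounts to an expected a number no higher from compound 2 to compound 4 (the limit leaves the size open). A report of only a limit is the likeliest outcome for compound 4 in this assay. Compound 4 is estimated at 100000 nM, with an expected range from 50000 nM to 200000 nM.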

Compound 4, half-maximal cytotoxic concentration: > 100000 nM
Compound 4: a limit, no number (the forecaster's own chance of this, stated with the estimate: 80%); the middle value lies on the limit itself.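

Compound 2 and compound 4 each return only a limit of the assay and not a number, so no step between them can be read in this assay: the limit of > 100000 nM in this assay, at which 4 of the 4 values shown sit.

The compounds shown leave open whether propyl and ethoxy differ at all in the tolerated concentration.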